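The compounds below may be only part of what the source reports. "The series", "measured", "known", "first", "only" and "open" are said of these compounds alone.

In a functional assay on A549 cells (Homo sapiens) for antiproliferative activity, read by MTT assay (on this read-out higher numbers stand for weaker inhibition and lower numbers for stronger inhibition), compound 1 (`COc1cc2c(Oc3ccc(NC(=O)Nc4ccccc4C(F)(F)F)cc3)ccnc2cc1OCCCCCCC(=O)NO`) gives 5280 nM, compound 2 (`COc1cc2c(Oc3ccc(NC(=O)Nc4ccc(C(F)(F)F)cc4Cl)cc3)ccnc2cc1OCCCCCCC(=O)NO`) gives 970 nM and compound 3 (`COc1cc2c(Oc3ccc(NC(=O)Nc4ccccc4F)cc3)ccnc2cc1OCCCCCCC(=O)NO`) gives 870 nM. Compound 3 thus shares the low end of these numbers with compound 2, as a 1.1-fold lower number from compound 2 to compound 3 (0.05 log units; within the scatter) shows. Compound 4 (`COc1cc2c(Oc3ccc(NC(=O)NNC(=O)c4ccccc4)cc3)ccnc2cc1OCCCCCCC(=O)NO`) carries benzamido in place of 2-fluorophenyl on an amide-type nitrogen. The measured steps only swap one substituted phenyl group for another, so none of them tests benzamido directly. The closest guides to size are the modest 6.1-fold lower number from compound 1 to compound 3 (0.78 log units; beyond the scatter) and a 5.4-fold lower number from compound 1 to compound 2 (0.74 log units; beyond the scatter). A step of similar modest size towards a higher number is expected, a 2.3-fold higher number from compound 3 to compound 4 (0.36 log units; beyond the scatter). For compound 4 the estimated value is 2000 nM, with an expected range of 550 nM to 7000 nM.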

Compound 4, half-maximal inhibitory concentration: 2820 nM
Compound 4: middle estimate off by 1.4-fold (0.15 log units), on the low side; the range from low to high includes it.
By their numbers in this assay, from the lowest: compounds 3 and 2 (each within the scatter of the next); then compounds 4 and 1 (each within the scatter of the next).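

In this assay, the amide-type nitrogen tolerates benzamido, which brings a hydrogen-bond donor and acceptor absent from 2-fluorophenyl, with only a modest loss against the two better phenyl ureas (a 3.2-fold higher number from compound 3 to compound 4 (0.51 log units; beyond the scatter); a 2.9-fold higher number from compound 2 to compound 4 (0.46 log units; beyond the scatter)). Against the 2-(trifluoromethyl)phenyl group, benzamido cannot be told apart (a 1.9-fold lower number from compound 1 to compound 4 (0.27 log units; within the scatter)). No measurement here explains these differences.

From the compounds shown here alone, whether an amine or a carboxylic acid at this position would fare better remains open. So does the effect of placing fluoro or chloro on the benzamido ring.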